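A few compounds are considered here, and "the series" means these few. Any claim that something is new, unique, unknown or untested is made for them only; others in the source may bear on it.

Measured compounds:
- compound 1, `COc1cccc(Oc2c(NS(=O)(=O)c3ccc(C(C)(C)C)cc3)ncnc2OCCOCc2ccccc2)c1`: 170 nM
- compound 2, `COc1cccc(Oc2c(NS(=O)(=O)c3ccc(C(C)(C)C)cc3)ncnc2OCCOc2ccncn2)c1`: 1.2 nM
- compound 3, `COc1cccc(Oc2c(NS(=O)(=O)c3ccc(C(C)(C)C)cc3)ncnc2OCCOc2ncc(C)cn2)c1`: 0.86 nM

In an assay on cells (Endothelial cell) for binding affinity to Endothelin-1 receptor (Sus scrofa) (on this read-out lower numbers stand for stronger inhibition and higher numbers for weaker inhibition), compound 3 gives the lowest of the three numbers, but compound 2 sits within the usual scatter of it, as a 1.4-fold lower number from compound 2 to compound 3 (0.14 log units; within the scatter) shows; only compound 1 stands clearly apart, with a 200-fold lower number from compound 1 to compound 3 (2.30 log units; beyond the scatter). The large steps of a 140-fold lower number from compound 1 to compound 2 (2.15 log units; beyond the scatter) and a 200-fold lower number from compound 1 to compound 3 (2.30 log units; beyond the scatter) both concern the exchange of the benzyl group for a pyrimidinyl ring on the ether oxygen, not anything on the pyrimidine itself.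

Compound 4, `COc1cccc(Oc2c(NS(=O)(=O)c3ccc(C(C)(C)C)cc3)ncnc2OCCOc2ncc(Br)cn2)c1`, differs from compound 3 in one place: bromo in place of methyl on an aromatic carbon. Going by the values given here, no measured step tests a change of this kind. Among the compounds with values here, the only step within the pyrimidine series, a 1.4-fold lower number from compound 2 to compound 3 (0.14 log units; within the scatter), moved the ring attachment and a methyl group and stayed within the scatter. On that basis, compound 4 is expected to show a step of about a 1.0-fold higher number from compound 3 to compound 4 (0.02 log units; within the scatter), nothing beyond the scatter. The estimate for compound 4 in this assay is 0.9 nM, in a range from 0.3 nM to 3 nM.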

Compound 4, half-maximal inhibitory concentration: 0.051 nM
For compound 4 the middle estimate is 18-fold (1.25 log units) above the measured one, outside the stated range (below it).
By their numbers in this assay, from the lowest: compound 4; then compounds 3 and 2 (each within the scatter of the next); then compound 1.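

In this assay, going by these compounds alone, the aromatic carbon of the 5-methylpyrimidin-2-yl ring proves sensitive to what it carries: exchanging one heavy atom, methyl, for bromo gives a 17-fold lower number from compound 3 to compound 4 (1.23 log units; beyond the scatter), a large step at a place the earlier compounds had not varied on its own. The 5-bromopyrimidin-2-yl ether also stands clear of the other pyrimidine ether, with a 24-fold lower number from compound 2 to compound 4 (1.37 log units; beyond the scatter), and it widens the gap to the benzyl ether, with a 3300-fold lower number from compound 1 to compound 4 (3.52 log units; beyond the scatter). Nothing among the data offers a measured reason for this gain.

The compounds shown leave open how chloro, iodo or a nitrile on the same aromatic carbon would compare with bromo in this assay. They also leave open whether bromo would give a step of like size on the pyrimidin-4-yl ring.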